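This account rests on a few compounds, and the source may have more. Where it says the series, first, only, none or still open, it means among the compounds named here.

Compound 1 `O=C(O)c1cc(-c2ccns2)ccc1O`: 80 mg/kg
Compound 2 `O=C(O)c1cc(-c2ccncn2)ccc1O`: a limit, > 200 mg/kg

Both compounds were tested in a functional assay on the whole organism for inhibition, with Rattus norvegicus as the target, read by paw edema; on this read-out lower numbers stand for an effect already at smaller amounts and higher numbers for an effect only at larger amounts of compound. For the measured compounds named here, compound 1 gives 80 mg/kg, the only real number among the values shown. Compound 2 returns only a limit, > 200 mg/kg, and so stands at the limit of > 200 mg/kg in this assay, at which 1 of the 2 values shown sits. Compound 3 `O=C(O)c1cc(-n2cnnc2)ccc1O` is not yet measured. It differs from compound 1 in one place: 4H-1,2,4-triazol-4-yl in place of 1,2-thiazol-5-yl on an aromatic carbon. Going by the values given here, no measured pair carries this exact change, so its size is open; what compound 1 and compound 2 show is that swapping the ring group on the shared core can push the result out to a limit. A step toward higher dose is therefore expected, a 2.0-fold higher number from compound 1 to compound 3 (0.30 log units; within the scatter), with a fair chance that only a limit is reported. Compound 3 is estimated at 160 mg/kg, in the range 60 mg/kg to 400 mg/kg.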

Compound 3, dose for half-maximal effect: > 250 mg/kg
Compound 3: only a limit was reported; the forecaster's own chance of this, stated with the estimate: 40%; middle value at least 1.5-fold (0.19 log units) away from the limit.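

On the shared core, at the aromatic carbon para to a hydroxy group and meta to a carboxy group, 4H-1,2,4-triazol-4-yl in place of 1,2-thiazol-5-yl gives, in this assay, an at least 3.1-fold higher number from compound 1 to compound 3 (0.49 log units; beyond the scatter). Compound 3 is reported only as a limit, not as a number: the limit of > 250 mg/kg in this assay, at which 1 of the 3 values shown sits. The two groups are both five-membered aromatic rings of the same heavy-atom count, so for this pair, matching ring size and heavy-atom count did not keep the value of compound 1.

The data do not show how large the step truly is, nor why this exchange of rings shifts the result so far. As far as these compounds go, it also remains open how a phenyl ring or an amine at this place would read out in this assay.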